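Working notes: aryl change on the ring nitrogen of compound 2

A few compounds are considered here, and "the series" means these few. Any claim that something is new, unique, unknown or untested is made for them only; others in the source may bear on it.

Measured so far:
compound 1 `CCCCN(CC)c1nc(C)nc2c1nnn2-c1c(C)cc(C)cc1C`, 27.5 nM
compound 2 `CCCC(CCC)Nc1nc(C)nc2c1nnn2-c1c(C)cc(C)cc1C`, 4 nM

In an in vitro assay on 293-EBNA cells for binding affinity to corticotropin-releasing factor receptor 1 (Homo sapiens) (a higher number here means a weaker inhibitor, a lower number a stronger inhibitor), compound 2 stands lowest of the two measured numbers; its nearest neighbour is compound 1, reached by a 6.9-fold lower number from compound 1 to compound 2 (0.84 log units; beyond the scatter). Compound 3 `CCCC(CCC)Nc1nc(C)nc2c1nnn2-c1ccc(Br)cc1Br` carries 2,4-dibromophenyl in place of 2,4,6-trimethylphenyl on an aromatic nitrogen. Going by the values given here, no measured step touches this position: the single step, from compound 1 to compound 2, alters the amino group. The expectation for this assay therefore rests on compound 2 alone, with a wide range and no firm direction, leaning towards no change beyond the scatter or a small rise. Compound 3 is estimated at 8 nM, range 2 nM to 40 nM, meaning an expected 2.0-fold higher number from compound 2 to compound 3 (0.30 log units; within the scatter).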

Compound 3, inhibition constant: 0.8 nM
Estimate against measurement, compound 3: 10-fold (1.00 log units) above; the measured number lies below the stated range.
By their numbers in this assay, from the lowest: compound 3; then compound 2; then compound 1.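

The aryl group on the ring nitrogen, untouched by the earlier step, also moves the number in this assay: 2,4-dibromophenyl in place of 2,4,6-trimethylphenyl gives a 5.0-fold lower number from compound 2 to compound 3 (0.70 log units; beyond the scatter). With the (1-propylbutyl)amino group held constant, 2,4,6-trimethylphenyl is therefore not needed for a low number. Nothing available explains the gain.

Going by these compounds, it remains open whether the same aryl change would give a similar step alongside the butyl(ethyl)amino group of compound 1. On these data alone, it is also open how 2,4-dichlorophenyl or 2,4-dimethoxyphenyl on this nitrogen would compare with 2,4-dibromophenyl.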